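The source may report more compounds than this note shows. Statements on the series, on what has been measured and on what is new or still open speak of the compounds shown alone.

In a functional assay on A549 cells (Homo sapiens) for cytotoxicity, read by MTT assay, with a stated time of 48 h (on this read-out higher numbers stand for weaker inhibition and lower numbers for stronger inhibition), compound 1 `COc1c(OCCCCNCc2ccccc2)cc(O)c2c(=O)cc(-c3ccccc3)oc12` gives 4590 nM and compound 3 `COc1c(OCCCCN2CCCCC2)cc(O)c2c(=O)cc(-c3ccccc3)oc12` gives 1150 nM, the lower of the two numbers available. Compound 2 `CC(C)NCCOc1c(O)cc(O)c2c(=O)cc(-c3ccccc3)oc12` offers no comparison, as its entry reads "not determined" (no result reported).

Compound 4 `COc1c(OCCCN2CCCC2)cc(O)c2c(=O)cc(-c3ccccc3)oc12` has not yet been measured. It differs from compound 3 by pyrrolidin-1-yl in place of (piperidin-1-yl)methyl on a saturated chain carbon, three bonds along the chain from an oxygen on an aromatic ring. Read one way, 4-(piperidin-1-yl)butyl gives way to 3-(pyrrolidin-1-yl)propyl.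

For the measured compounds named here, only one measured step bears on this change: a 4.0-fold lower number from compound 1 to compound 3 (0.60 log units; beyond the scatter), modest but beyond the scatter, with piperidin-1-yl in place of benzylamino. Going by the values given here, compound 3 and compound 4 both end in a non-aromatic ring, and no measured step shows what this kind of change does. A smaller step than that one is therefore expected in this assay, with no firm direction and nothing beyond the scatter.

The expected step is a 1.3-fold higher number from compound 3 to compound 4 (0.12 log units; within the scatter). The estimated value for compound 4 is 1500 nM, with an expected range of 500 nM to 4500 nM.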

Compound 4, half-maximal inhibitory concentration: 1390 nM
Compound 4: middle estimate off by 1.1-fold (0.03 log units), on the high side; low and high end bracket the measured number.
By their numbers in this assay, from the lowest: compounds 3 and 4 (each within the scatter of the next); then compound 1.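

In this assay the exchange of 4-(piperidin-1-yl)butyl for 3-(pyrrolidin-1-yl)propyl gives a 1.2-fold higher number from compound 3 to compound 4 (0.08 log units; within the scatter) and so, on a saturated chain carbon, three bonds along the chain from an oxygen on an aromatic ring, a change of ring and chain together leaves two numbers that cannot be told apart. The earlier compounds shown here showed only a benzylamino end against a piperidine end, and the new ring end also separates from the benzylamino end, with a 3.3-fold lower number from compound 1 to compound 4 (0.52 log units; beyond the scatter) in the same assay. No measurement shown here gives a reason for either step.

Ring size and chain length change together in this step, so the compounds shown cannot separate one from the other. On these data alone, it also remains open how a morpholine ring, a dimethylamino end or a longer chain would fare on the same core.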